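Methoxy to hydroxy on the aryl ring of compound 3

The compounds below may be only part of what the source reports. "The series", "measured", "known", "first", "only" and "open" are said of these compounds alone.

Measured so far in a functional assay on MOLT-4 cells (Homo sapiens) for cytotoxicity, read by sulforhodamine B assay, with a stated time of 48 h, tested at 100 nM; a lower number here means a stronger effect, a higher number a weaker effect of the compound at the concentration tested:
compound 1, `COc1cc(C)cc(-c2nn(CC#N)cc2-c2ccc(-c3cccc(C(C)=O)c3)nc2)c1`, gives 84%;
compound 2, `Cc1cc(O)cc(-c2nn(CC#N)cc2-c2ccnc(-c3ccc(Oc4ccccc4)cc3)c2)c1`, gives 79%;
compound 3, `COc1cc(C)cc(-c2nn(CC#N)cc2-c2ccnc(-c3ccc(N(C)C)cc3)c2)c1`, gives 39%.

Among these three, compound 3 stands with the lowest number in this assay, and the gap to each of the other two is beyond the scatter: compound 2 lies nearest, compound 1 furthest. Compound 1 and compound 2 themselves lie within the scatter of each other, so nothing separates them here.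

The piece now turns to compound 4, `Cc1cc(O)cc(-c2nn(CC#N)cc2-c2ccnc(-c3ccc(N(C)C)cc3)c2)c1`, which has not yet been measured. It differs from compound 3 in a single place:

hydrogen in place of methyl on an oxygen on an aromatic ring

Read one bond further out, the change is methoxy to hydroxy, that is 3-methoxy-5-methylphenyl to 3-hydroxy-5-methylphenyl. Among the compounds with values here, no measured pair in this set shows this change alone, so its size cannot be read off from the numbers. Compound 2 does carry the hydroxy form of this ring, but its other aryl group differs from that of compound 3, and the numbers of compound 2 and compound 3 therefore say nothing about the oxygen substituent by itself.

The expected step from compound 3 to compound 4 in this assay is small, a step of a number 7 percentage points higher from compound 3 to compound 4 (within the scatter), most likely within the scatter. For compound 4 the estimated value in this assay is 46%, with a range from 25% to 70%.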

Compound 4, a percentage reported as activity, at one concentration (the size of the read-out at that concentration, not a potency): 89%
Compound 4: middle estimate off by 43 percentage points, on the low side; measured number above the stated range.
By their numbers in this assay, from the lowest: compound 3; then compounds 2, 1 and 4 (each within the scatter of the next).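

In this assay, within the data shown here, the oxygen on the aromatic ring proves to be a sensitive place: hydrogen in place of methyl there gives a number 50 percentage points higher from compound 3 to compound 4 (beyond the scatter), the first reading of this change on its own. The dimethylamino group therefore does not by itself account for the low number of compound 3 at 39%, since compound 4 carries the same group and loses that number once the methyl on the oxygen is gone. With the hydroxy form of the ring held constant, dimethylamino in place of phenoxy on an aromatic carbon gives a number 10 percentage points higher from compound 2 to compound 4 (within the scatter), so the two groups are not separated in that setting, and the low number is seen only where the methoxy form and the dimethylamino group occur together.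

As far as these compounds go, it remains open whether an ethyl group or a longer chain on that oxygen would keep the number of compound 3, and whether an amine in place of the oxygen would behave like the methoxy or the hydroxy form. Nothing available bears on why removing this methyl has so large a step.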